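The source may hold more compounds than are shown below. What is called first, only, known or untested is meant among the compounds shown, and "the series" means these compounds.

Compound 2 `CCN(CC)C(=O)CCC(=O)Oc1ccc(C[C@H]2C(=O)OC[C@@H]2Cc2ccc(OC)c(OC)c2)cc1OC` is the reference point for this step; in an ADME assay on HeLa cells (Homo sapiens) for cytotoxicity, read by MTT assay (on this read-out lower numbers stand for stronger inhibition and higher numbers for weaker inhibition), compound 2 gives 213000 nM. Compound 1 `COc1ccc(C[C@H]2COC(=O)[C@@H]2Cc2ccc(OCc3cn(Cc4ccc(Cl)cc4)nn3)c(OC)c2)cc1OC` gives 242000 nM and compound 3 `COc1ccc(C[C@H]2COC(=O)[C@@H]2Cc2ccc(OCc3cn(Cc4ccccc4)nn3)c(OC)c2)cc1OC` gives 346000 nM, so all three numbers lie within the scatter of each other. Among the measured compounds shown here, the only single-point step recorded is a 1.4-fold higher number from compound 1 to compound 3 (0.16 log units; within the scatter), a change far from the present one. Compound 4 `COc1ccc(C[C@H]2COC(=O)[C@@H]2Cc2ccc(OCc3cn(-c4ccccc4)nn3)c(OC)c2)cc1OC` carries a group of 12 heavy atoms (9 carbon, 3 nitrogen; one five-membered aromatic ring with 3 hetero atoms, one six-membered aromatic ring of carbon only) in place of a group of 11 heavy atoms (8 carbon, 1 nitrogen, 2 oxygen; no ring), on an oxygen on an aromatic ring. For the measured compounds named here, no measured step touches this part of the structure, yet compounds 1 and 3 already carry a triazolylmethyl group on the same oxygen and sit with compound 2 inside the scatter. For compound 4 in this assay no step beyond the scatter is expected, a 1.4-fold higher number from compound 2 to compound 4 (0.13 log units; within the scatter). Compound 4 is estimated at 290000 nM, within the range 140000 nM to 600000 nM.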

Compound 4, half-maximal inhibitory concentration: 124000 nM
Beside the measured number, compound 4's estimate is 2.3-fold (0.37 log units) above it, outside the stated range (below it).
By their numbers in this assay, from the lowest: compounds 4, 2, 1 and 3 (each within the scatter of the next, the first and the last beyond it).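

In this assay, among the compounds shown here, phenyl in place of benzyl on an aromatic nitrogen gives the only new step beyond the scatter, though a modest one (a 2.8-fold lower number from compound 3 to compound 4 (0.45 log units; beyond the scatter)). Phenyl in place of 4-chlorobenzyl stays within the scatter (a 2.0-fold lower number from compound 1 to compound 4 (0.29 log units; within the scatter)), as does the (1-phenyl-1H-1,2,3-triazol-4-yl)methyl group on the oxygen on an aromatic ring (a 1.7-fold lower number from compound 2 to compound 4 (0.23 log units; within the scatter)). No measurement shown accounts for these steps.
As far as these compounds go, whether a 4-chlorophenyl or phenethyl group on that aromatic nitrogen would give a number beyond the scatter from compound 4 remains open.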